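The source may report more compounds than this note shows. Statements on the series, on what has been measured and on what is new or still open speak of the compounds shown alone.

Compound 2 `COc1ccc(-c2cc(OC)cc(C(=O)Nc3nn[nH]n3)n2)cc1` serves as the reference. In a functional assay on the whole organism for inhibition, with Rattus norvegicus as the target, at a dose of 1 mg/kg by the oral route (on this read-out lower numbers stand for a weaker effect and higher numbers for a stronger effect at the one dose given), compound 2 gives 25%, the second highest of the three numbers measured. Compound 1 `COc1cc(C(=O)Nc2nn[nH]n2)nc(-c2ccccc2OC)c1` gives 41%, and the step of a number 16 percentage points lower from compound 1 to compound 2 (beyond the scatter) lies beyond the scatter. Compound 3 `COc1cc(C(=O)Nc2nn[nH]n2)nc(-c2ccc(OC)c(OC)c2)c1` gives 18%, and the step of a number 7 percentage points lower from compound 2 to compound 3 (within the scatter) stays within the scatter. Compound 4 `CCCCc1ccc(-c2cc(OC)cc(C(=O)Nc3nn[nH]n3)n2)cc1` differs from compound 2 in one place: butyl in place of methoxy on an aromatic carbon. Within the data shown here, neither measured step bears directly on this change, as one shifts a methoxy to another position and the other adds a methoxy; the only guide is that a single change on this ring moved the number by a modest amount at most. The expected step is therefore no change at the digits printed from compound 2 to compound 4 (within the scatter), none beyond the scatter. Compound 4 is estimated at 25%, with a range from 5% to 50%.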

Compound 4, a percentage reported as inhibition, in the whole organism at one dose (the size of the read-out at that dose, not a potency): 29%
Compound 4: the middle estimate sits 4 percentage points below what was measured; the measured number falls inside the stated range.
By their numbers in this assay, from the lowest: compounds 3, 2 and 4 (each within the scatter of the next, the first and the last beyond it); then compound 1.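

In this assay, butyl in place of methoxy, para to a large group, gives a number 4 percentage points higher from compound 2 to compound 4 (within the scatter). For this pair, then, an all-carbon chain with no hydrogen-bond acceptor stays within the scatter of the methoxy, which has one, so the methoxy oxygen is not needed to keep this level of effect at the one dose given. No measurement here accounts for this result.

From the compounds shown here alone, whether a longer chain, an amine or a carboxylic acid at this position would keep this level remains open. A single dose also shows only how strong the effect is at that dose.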